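The source may report more compounds than this note shows. Statements on the series, on what has been measured and on what is new or still open speak of the compounds shown alone.

Working notes on the series.

In a functional assay on CHO cells for agonist activity at Free fatty acid receptor 1 (Homo sapiens), read by FLIPR and calcium flux (on this read-out lower numbers stand for an effect already at smaller amounts and higher numbers for an effect only at larger amounts of compound), compound 3 `N#Cc1ccccc1-c1cccc(CNc2ccc(OCC(=O)O)c(F)c2)c1` gives 729 nM. Of the two numbers shown this is the higher one; the nearest, compound 2 `CCCOc1cc(C)c(-c2cccc(CNc3ccc(OCC(=O)O)c(F)c3)c2)c(C)c1`, gives 38.7 nM in this assay, and the gap between the two is beyond the scatter. Compound 1 `CCOc1cc(C)c(-c2cccc(COc3ccc(NCC(=O)O)c(F)c3)c2)c(C)c1` yields only > 1000 nM in this assay, which is a limit and not a number. Within the data shown here, compound 2 and compound 3 differ in more than one place, so their two values show only that the lower number goes with the propoxy-dimethylphenyl biphenyl and the higher with the cyanophenyl one.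

The step to compound 4 `Cc1cc(O)ccc1-c1cccc(CNc2ccc(OCC(=O)O)c(F)c2)c1` is a single change: 4-hydroxy-2-methylphenyl in place of 2-cyanophenyl on an aromatic carbon. No measured pair isolates this change, so its size cannot be read off from the numbers shown. The expectation is that the step from compound 3 to compound 4 in this assay is a downward one, estimated at a 4.9-fold lower number from compound 3 to compound 4 (0.69 log units; beyond the scatter), beyond the scatter, because compound 2 reaches 38.7 nM with a substituted phenyl in this position. For compound 4 the estimate in this assay is 150 nM, with a range from 40 nM to 600 nM.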

Compound 4, half-maximal effective concentration: 69.6 nM
Estimate against measurement, compound 4: 2.2-fold (0.33 log units) above; the measured number falls inside the stated range.
By their numbers in this assay, from the lowest: compounds 2 and 4 (each within the scatter of the next); then compound 3. At a limit, above all of these: compound 1.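

The place on an aromatic carbon, meta to a large group, now has a step of its own in this assay: with 4-hydroxy-2-methylphenyl in place of 2-cyanophenyl there is a 10-fold lower number from compound 3 to compound 4 (1.02 log units; beyond the scatter). The read-out therefore depends strongly on which substituted phenyl stands at this place, even though both groups are six-membered aromatic rings of carbon only and carry no net charge. Compound 2 and compound 4 lie within the scatter of each other, so among the compounds shown a low number is not tied to the propoxy-dimethylphenyl group alone, and nothing at hand gives a measured reason for the size of the step.

The compounds shown leave open whether the hydroxy group, the methyl group or both together account for the step, as no compound here carries one of them without the other at this place. Also open, on these data alone, is how the number would respond to an amine or a carboxylic acid in place of the hydroxy group on this ring.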